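Methoxy for chloro on an indole-based cytotoxic series

The compounds below may be only part of what the source reports. "The series", "measured", "known", "first", "only" and "open" are said of these compounds alone.

Measured so far:
Compound 1 `CC1=NNC(=O)C1C(c1c[nH]c2ccccc12)c1c(-c2ccccc2)[nH]c2ccc(C)cc12`: 1300 nM
Compound 2 `CC1=NNC(=O)C1C(c1c[nH]c2ccccc12)c1c(-c2ccccc2)[nH]c2ccc(Cl)cc12`: 1600 nM

Of the compounds shown here, two have been measured in a functional assay on A549 cells (Homo sapiens) for cytotoxicity, read by MTT assay; a lower number here means a stronger inhibitor, a higher number a weaker inhibitor. Compound 1 `CC1=NNC(=O)C1C(c1c[nH]c2ccccc12)c1c(-c2ccccc2)[nH]c2ccc(C)cc12` gives 1300 nM, and compound 2 `CC1=NNC(=O)C1C(c1c[nH]c2ccccc12)c1c(-c2ccccc2)[nH]c2ccc(Cl)cc12` gives 1600 nM. Going by the values given here, the single step between them, a 1.2-fold higher number from compound 1 to compound 2 (0.09 log units; within the scatter), is a small one, so on these two numbers compound 2 stands with the higher value but within the scatter of compound 1; no order between them can be read.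

The next compound, compound 3 `COc1ccc2[nH]c(-c3ccccc3)c(C(c3c[nH]c4ccccc34)C3C(=O)NN=C3C)c2c1`, has not yet been measured. It differs from compound 2 in one place: methoxy in place of chloro on an aromatic carbon. Among the compounds with values here, no measured step bears directly on methoxy in this place; the only step available, a 1.2-fold higher number from compound 1 to compound 2 (0.09 log units; within the scatter), concerns the same aromatic carbon and was within the scatter. With that single precedent, an exchange at this position is expected to move the value little, and no change beyond the scatter is expected in this assay.

On that basis compound 3 is estimated at 1400 nM, in the range 600 nM to 3500 nM. The step this estimate implies is a 1.1-fold lower number from compound 2 to compound 3 (0.06 log units; within the scatter), which is expected to stay within the scatter.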

Compound 3, half-maximal inhibitory concentration: 2700 nM
Compound 3: middle estimate off by 1.9-fold (0.29 log units), on the low side; low and high end bracket the measured number.
By their numbers in this assay, from the lowest: compounds 1, 2 and 3 (each within the scatter of the next, the first and the last beyond it).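

In this assay the exchange of chloro for methoxy gives a 1.7-fold higher number from compound 2 to compound 3 (0.23 log units; within the scatter), so taken alone this change cannot be read as a real loss or gain on this aromatic carbon. Going by these compounds alone, the comparison with methyl, however, gives a 2.1-fold higher number from compound 1 to compound 3 (0.32 log units; beyond the scatter), the first step at this position to pass the scatter, if only modestly, so the position is not wholly indifferent to the group it carries, which compounds 1 and 2 could not show. Compound 2 lies within the scatter of both neighbours, and the data offer no measurement that accounts for the step from methyl to methoxy.

The three compounds leave open whether a hydroxy group, an amine or a carboxylic acid on this aromatic carbon would move the number further than methoxy does, and whether a longer chain such as ethoxy would extend the same step. They also leave open how plain hydrogen at this carbon compares with all three groups, and whether the modest step seen here holds when the rest of the shared core is changed.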